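Replacing the Nitro Group on the Sulfonate Aryl Ring

The source may report more compounds than this note shows. Statements on the series, on what has been measured and on what is new or still open speak of the compounds shown alone.

Three compounds have been measured in an assay on HEK293 cells for antagonist activity at P2X purinoceptor 7 (Homo sapiens), read by fluorescence, with a stated time of 2 h; a lower number here means a stronger inhibitor, a higher number a weaker inhibitor:

Compound 1, `O=C(c1ccc(Cl)c(C(F)(F)F)c1)N1CCC(n2cncc2-c2ccc(OS(=O)(=O)c3cccc4ccccc34)cc2)CC1`, gives 3520 nM.
Compound 2, `Nc1cccc(S(=O)(=O)Oc2ccc(-c3cncn3C3CCN(C(=O)c4ccc(Cl)c(C(F)(F)F)c4)CC3)cc2)c1`, gives 565 nM.
Compound 3, `O=C(c1ccc(Cl)c(C(F)(F)F)c1)N1CCC(n2cncc2-c2ccc(OS(=O)(=O)c3cccc([N+](=O)[O-])c3)cc2)CC1`, gives 249 nM.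

Compound 3 stands lowest of the three: a 2.3-fold lower number from compound 2 to compound 3 (0.36 log units; beyond the scatter), and a 14-fold lower number from compound 1 to compound 3 (1.15 log units; beyond the scatter). Compound 4, `CNC(=O)c1cccc(S(=O)(=O)Oc2ccc(-c3cncn3C3CCN(C(=O)c4ccc(Cl)c(C(F)(F)F)c4)CC3)cc2)c1`, differs from compound 3 by methylcarbamoyl in place of nitro on an aromatic carbon. Among the compounds with values here, no measured step exchanges nitro for methylcarbamoyl directly; the steps that bear on it are those at the same aromatic carbon, namely a 6.2-fold lower number from compound 1 to compound 2 (0.79 log units; beyond the scatter) and a 2.3-fold lower number from compound 2 to compound 3 (0.36 log units; beyond the scatter). Both aryl substituents gave numbers far below compound 1, and differed only modestly from each other. A modest rise is therefore expected, a 2.0-fold higher number from compound 3 to compound 4 (0.30 log units; within the scatter). For compound 4 the estimate in this assay is 500 nM, with a range from 150 nM to 1800 nM.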

Compound 4, half-maximal inhibitory concentration: 112 nM
The estimate for compound 4 lay 4.5-fold (0.65 log units) above the measured number; the measured number lies below the stated range.
By their numbers in this assay, from the lowest: compound 4; then compound 3; then compound 2; then compound 1.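

In this assay the nitro group proves not to be needed at this aromatic carbon, since methylcarbamoyl gives a 2.2-fold lower number from compound 3 to compound 4 (0.35 log units; beyond the scatter) and a 5.0-fold lower number from compound 2 to compound 4 (0.70 log units; beyond the scatter) while the gain over the naphthalen-1-yl sulfonate widens to a 31-fold lower number from compound 1 to compound 4 (1.50 log units; beyond the scatter) among these compounds. The 3-(methylcarbamoyl)phenyl group, which brings in the amide hydrogen, is therefore the best-performing of the three substituted phenyl or fused aryl groups shown. Nothing measured here explains why this change lowers the number.

Going by these compounds, whether the amide hydrogen matters remains open, and a dimethylcarbamoyl group would address that. The compounds also leave open how a carboxylic acid or an amide with a longer chain would behave at this carbon.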